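Acetyl in place of ethyl: outlook for compound 4

The source may report more compounds than this note shows. Statements on the series, on what has been measured and on what is new or still open speak of the compounds shown alone.

Of the compounds shown here, three have been measured in an ADME assay on the whole organism with Oryza sativa as the target, tested at 0.1 uM; on this read-out higher numbers stand for a weaker effect at the one concentration tested and lower numbers for a stronger effect. Compound 1 `Cc1ccccc1NC(=O)N[C@H](C)c1ccccc1` gives 100%. Compound 2 `CCc1cccc(NC(=O)N[C@H](C)c2ccccc2)c1` gives 97%, and compound 3 `CCc1cccc(NC(=O)N[C@@H](C)c2ccccc2)c1` gives 100%; the three numbers sit within the usual scatter of one another, so compound 2 stands level with both. For the measured compounds named here, the only step between neighbours, a number 3 percentage points higher from compound 2 to compound 3 (within the scatter), rests on the fact that compounds 2 and 3 differ only in the configuration as drawn and leaves the aromatic substituent untouched. Compound 4 `CC(=O)c1cccc(NC(=O)N[C@H](C)c2ccccc2)c1` differs from compound 2 by acetyl in place of ethyl on an aromatic carbon. Going by the values given here, no measured step addresses an exchange of this kind, so there is no basis for expecting a shift beyond the scatter in this assay. Compound 4 is therefore estimated at 98%, with a range from 88% to 100%. The step expected is a number 1 percentage points higher from compound 2 to compound 4 (within the scatter).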

Compound 4, a percentage reported as activity, at one concentration (the size of the read-out at that concentration, not a potency): 98%
For compound 4 middle estimate and measured number coincide at the digits printed; the measured number falls inside the stated range.
By their numbers in this assay, from the lowest: compounds 2, 4, 1 and 3 (each within the scatter of the next).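

In this assay acetyl in place of ethyl on an aromatic carbon, meta to a large group, gives a number 1 percentage points higher from compound 2 to compound 4 (within the scatter). For the compounds shown here, this is the first step to change the aromatic substituent, and at this position the added hydrogen-bond acceptor and double bond outside aromatic rings leave the read-out within the scatter. Nothing at hand accounts for this step.

On these data alone, whether an amine or a carboxylic acid at this position would move the read-out beyond the scatter remains open. So does whether acetyl gives the same read-out with the configuration drawn in compound 3.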